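Swapping an aryl ether on a shared quinoline-free core

A few compounds are considered here, and "the series" means these few. Any claim that something is new, unique, unknown or untested is made for them only; others in the source may bear on it.

Measured so far:
compound 1, `COc1ccc(Oc2ccc3c(NCCCNCc4cc(F)ccc4OC)ccnc3c2)cc1`, gives 317 10^-6 cm/s in an ADME assay for permeability, using PAMPA, with a stated time of 30 min, at pH 7.4; on this read-out higher numbers stand for higher permeability and lower numbers for lower permeability.
compound 2, `COc1ccc(F)cc1CNCCCNc1ccnc2cc(Oc3cccc(N(C)C)c3)ccc12`, gives 317 10^-6 cm/s in this assay.
compound 3, `COc1ccc(Oc2ccc3c(NCCCNCc4cccc(OC)c4O)ccnc3c2)cc1`, gives 317 10^-6 cm/s in this assay.

Compound 4, `COc1cccc(CNCCCNc2ccnc3cc(Oc4cccc(N(C)C)c4)ccc23)c1O`, has not yet been measured. Compound 1 becomes compound 2 through (3-(dimethylamino)phenyl in place of 4-methoxyphenyl on an oxygen on an aromatic ring), and that change gave no change at the digits printed from compound 1 to compound 2 (within the scatter). The same change, at a place described in the same words, turns compound 3 into compound 4: 3-(dimethylamino)phenyl in place of 4-methoxyphenyl on an oxygen on an aromatic ring. The cores of compound 3 and compound 1 differ by 2-hydroxy-3-methoxyphenyl in place of 5-fluoro-2-methoxyphenyl on a saturated chain carbon bound to an amine nitrogen, and that difference gave no change at the digits printed from compound 1 to compound 3 (within the scatter). Since every measured compound sits at the same reading, the step from compound 3 to compound 4 is expected to be about no change at the digits printed from compound 3 to compound 4 (within the scatter), resting on no change at the digits printed from compound 1 to compound 2 (within the scatter). Compound 4 is therefore estimated at 317 10^-6 cm/s, with a likely range from 160 10^-6 cm/s to 320 10^-6 cm/s.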

Compound 4, apparent permeability in the ADME assay: 317 10^-6 cm/s
The estimate for compound 4 equals the measured number at the digits printed, and the stated range covers the measured number.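

In the ADME assay, compound 3 gives 317 10^-6 cm/s and compound 4 gives 317 10^-6 cm/s; putting 3-(dimethylamino)phenyl in place of 4-methoxyphenyl gives no change at the digits printed from compound 3 to compound 4 (within the scatter), matching the same change on the other core: the same change on two cores in the ADME assay, no change at the digits printed (within the scatter) from compound 1 to compound 2 and no change at the digits printed (within the scatter) from compound 3 to compound 4, 1.0-fold (0.00 log units) apart, within the scatter of two such steps
Putting 2-hydroxy-3-methoxyphenyl in place of 5-fluoro-2-methoxyphenyl gives no change at the digits printed from compound 2 to compound 4 (within the scatter), which also matches its earlier step: the same change on two cores in the ADME assay, no change at the digits printed (within the scatter) from compound 1 to compound 3 and no change at the digits printed (within the scatter) from compound 2 to compound 4, 1.0-fold (0.00 log units) apart, within the scatter of two such steps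
With all four compounds at one reading, this shows that both changes left the reading level on the cores tested, but not that a change that moves the reading would carry over in the same way, or that other cores would behave alike.

In a physicochemical assay for acid dissociation, compound 3 gives 9.28 and compound 4 gives 9.28. In the physicochemical assay, the only step shown is no change at the digits printed from compound 3 to compound 4 (within the scatter), so whether it holds on the core of compound 1 stays open. Also open, going by these compounds, is how a carboxylic acid in place of the 3-(dimethylamino)phenyl group would read in either assay.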